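A few compounds are considered here, and "the series" means these few. Any claim that something is new, unique, unknown or untested is made for them only; others in the source may bear on it.

Measured compounds:
compound 1 `CC(C)OC(=O)C1=CN(C(=O)c2ccc(C#N)cc2)CC(C)(C)c2cc(C#N)[nH]c21`, in an assay on HEK293 cells for agonist activity at Bile acid receptor (Homo sapiens), read by a luciferase reporter (on this read-out lower numbers stand for smaller maximal responses and higher numbers for larger maximal responses), compound 1 gives 116%
compound 2 `CC(C)OC(=O)C1CN(C(=O)c2cccc(Cl)c2)CC(C)(C)c2cc(C#N)[nH]c21`, in this assay compound 2 gives 103%
compound 3 `CC(C)OC(=O)C1CN(C(=O)c2ccc(C#N)cc2)CC(C)(C)c2cc(C#N)[nH]c21`, in this assay compound 3 gives 91%

Compound 1 stands highest of the three numbers in this assay; compound 2 lies lower, compound 3 lower still, both beyond the scatter. Compound 4 `CC(C)OC(=O)C1=CN(C(=O)c2ccc(F)cc2)CC(C)(C)c2cc(C#N)[nH]c21` differs from compound 1 in one place: fluoro in place of cyano on an aromatic carbon. Among the compounds with values here, the only measured step on the same phenyl ring is a number 12 percentage points lower from compound 2 to compound 3 (beyond the scatter), which sets 3-chlorophenyl against 4-cyanophenyl and is modest in size. Within the data shown here, no measured step exchanges cyano for fluoro, so the bearing of that step is indirect. With the nitrile leaving and all three measured numbers lying at or above full response, a small downward step or none beyond the scatter is expected for compound 4: a number 8 percentage points lower from compound 1 to compound 4 (within the scatter). Compound 4 is therefore estimated at 108%, in the range 90% to 124%.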

Compound 4, largest response reached (reported as efficacy), in percent of the reference or control that the assay uses: 119%
Compound 4: the middle estimate sits 11 percentage points below what was measured, within the range that was stated.
By their numbers in this assay, from the lowest: compound 3; then compound 2; then compounds 1 and 4 (each within the scatter of the next).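

Exchanging the nitrile for fluoro on this aromatic carbon gives a number 3 percentage points higher from compound 1 to compound 4 (within the scatter) in this assay. The 4-cyanophenyl group of compound 1 is therefore not needed to hold this maximal response on this core, since 4-fluorophenyl in compound 4 serves equally well. Nothing available accounts for this tolerance.

Still open, going by these compounds, is whether the same exchange holds on the core of compound 3. On these data alone, it is also open whether a larger group, such as methoxy, or an amine at this aromatic carbon would keep the response.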